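The compounds below may be only part of what the source reports. "The series", "measured", "known", "first", "only" and "open" are said of these compounds alone.

Four compounds share one core and differ only in a side chain that hangs from a saturated chain carbon bound to a saturated ring carbon. Compound 1 `CC(C)(O/N=C(\C(=O)N[C@@H]1C(=O)N(S(=O)(=O)O)[C@@H]1CN1C[C@H](CN)OC1=O)c1csc(N)n1)C(=O)O` carries a five-membered non-aromatic ring there, and compound 2 `CC(C)(O/N=C(\C(=O)N[C@@H]1C(=O)N(S(=O)(=O)O)[C@@H]1CN1C[C@H](CNC(=N)N)OC1=O)c1csc(N)n1)C(=O)O` is the same molecule with a small group added on an amine nitrogen. Compound 3 `CC(C)(O/N=C(\C(=O)N[C@@H]1C(=O)N(S(=O)(=O)O)[C@@H]1Cn1ncnc1CN)c1csc(N)n1)C(=O)O` carries a five-membered aromatic ring in place of that non-aromatic ring instead, as counted in a group of 7 heavy atoms (3 carbon, 4 nitrogen; one five-membered aromatic ring with 3 hetero atoms) in place of a group of 8 heavy atoms (4 carbon, 2 nitrogen, 2 oxygen; one five-membered non-aromatic ring with 2 hetero atoms), on a saturated chain carbon bound to a saturated ring carbon. Compound 4 `CC(C)(O/N=C(\C(=O)N[C@@H]1C(=O)N(S(=O)(=O)O)[C@@H]1Cn1ncnc1CNC(=N)N)c1csc(N)n1)C(=O)O` is compound 3 with the same small group added on its amine nitrogen.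

In a physicochemical assay for metabolic stability, read by HPLC and mass spectrometry, in phosphate buffer, at 37 degrees C, at pH 7.4 (a lower number here means that the compound disappears faster, a higher number that the compound lasts longer), compound 1 gives > 37 h, which is a limit of the assay and not a number. In this assay compound 2 gives > 37 h, again a limit. In this assay compound 3 gives > 37 h, also a limit.

The change from compound 1 to compound 2 is a group of 3 heavy atoms (1 carbon, 2 nitrogen; no ring) in place of a hydrogen atom, on an amine nitrogen. Its step, a step that the two limits leave unreadable from compound 1 to compound 2, cannot be sized, since both ends sit at the limit (the limit of > 37 h in this assay, at which 3 of the 3 values shown sit). The change from compound 3 to compound 4 is a group of 3 heavy atoms (1 carbon, 2 nitrogen; no ring) in place of a hydrogen atom, on an amine nitrogen, and its place reads the same in every word, so it is the same change applied to a different core.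

For compound 4 the step that the limit leaves unreadable from compound 3 to compound 4 is expected to be as unreadable as the earlier one, resting on compound 3 sitting at > 37 h together with the other two values at the limit of > 37 h in this assay, at which 3 of the 3 values shown sit. Compound 4 is therefore estimated to reach 80 h, most likely reported as a limit again.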

Compound 4, half-life: > 37 h
Compound 4 gave a limit, no number; the forecaster's own chance of this, stated with the estimate: 85%; the middle value lies beyond the limit too.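

In this assay, for the compounds shown here, no step can be sized among compound 1, compound 2, compound 3 and compound 4, because each value is a limit and not a number: the limit of > 37 h in this assay, at which 4 of the 4 values shown sit. The compounds shown leave open how long each one actually lasts, and so whether the added group of 3 heavy atoms or the exchange of the five-membered ring changes that at all.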